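This account rests on a few compounds, and the source may have more. Where it says the series, first, only, none or still open, it means among the compounds named here.

In a functional assay (lung parenchyma) for displacement of a labelled ligand, with Cavia porcellus as the target (on this read-out higher numbers stand for weaker inhibition and lower numbers for stronger inhibition), compound 1 (`COc1cc(C(=O)NS(=O)(=O)c2ccccc2C)ccc1Cn1cc(C)c2ccc(C(=O)NCC3CCCC3)cc21`) gives 9.89 nM; 9.89 nM (2 entries), compound 2 (`COc1cc(C(=O)NS(=O)(=O)c2ccccc2C)ccc1Cn1cc(CC(C)C(=O)N(C)C)c2ccc(C(=O)NCC3CCCC3)cc21`) gives 2.32 nM and compound 3 (`CCN(CC)C(=O)CCc1cn(Cc2ccc(C(=O)NS(=O)(=O)c3ccccc3C)cc2OC)c2cc(C(=O)NCC3CCCC3)ccc12`) gives 0.54 nM, the lowest number of the three. The next entry, compound 4 (`CCN(CC)C(=O)/C=C/c1cn(Cc2ccc(C(=O)NS(=O)(=O)c3ccccc3C)cc2OC)c2cc(C(=O)NCC3CCCC3)ccc12`), alters only the side chain of compound 3: 2-(diethylcarbamoyl)ethenyl in place of 2-(diethylcarbamoyl)ethyl on an aromatic carbon. In words, 2-(diethylcarbamoyl)ethenyl stands in place of 2-(diethylcarbamoyl)ethyl on an aromatic carbon of the five-membered aromatic ring.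

Among the measured compounds shown here, the only measured step within this side chain is a 4.3-fold lower number from compound 2 to compound 3 (0.63 log units; beyond the scatter), a modest change. It swaps the substituents of the chain and does not introduce a double bond, so it offers a rough scale but no direction. For the measured compounds named here, no measured pair isolates the change from a saturated chain to an unsaturated one. A step no larger than that one is therefore expected in this assay, probably within the scatter, with a slight lean towards a higher number. The expected step is a 1.9-fold higher number from compound 3 to compound 4 (0.27 log units; within the scatter). For compound 4 the estimated value is 1 nM, with an expected range from 0.3 nM to 3.5 nM.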

Compound 4, inhibition constant: 4.9 nM
For compound 4 the middle estimate is 4.9-fold (0.69 log units) below the measured one; measured number above the stated range.
By their numbers in this assay, from the lowest: compound 3; then compound 2; then compound 4.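

In this assay, among the compounds shown here, the saturation of the side chain on this aromatic carbon matters: 2-(diethylcarbamoyl)ethenyl in place of 2-(diethylcarbamoyl)ethyl gives a 9.1-fold higher number from compound 3 to compound 4 (0.96 log units; beyond the scatter), the first step that isolates the double bond, with heavy atoms, hydrogen-bond counts and charge unchanged. This step is larger than a 4.3-fold lower number from compound 2 to compound 3 (0.63 log units; beyond the scatter), and a 2.1-fold higher number from compound 2 to compound 4 (0.32 log units; beyond the scatter) places the ethenyl chain on the weaker side of the 2-(dimethylcarbamoyl)propyl chain as well. No measurement at hand accounts for the effect of the double bond.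

The compounds shown leave open whether the weaker inhibition follows any unsaturated link or only this ethenyl geometry, which a 2-(diethylcarbamoyl)ethynyl chain or the opposite double-bond isomer would test. They also leave open how far the diethylcarbamoyl end can be replaced, for instance by a carboxylic acid.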